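Chalcone-linked series: second trimethoxyphenyl on the five-membered ring

The source may report more compounds than this note shows. Statements on the series, on what has been measured and on what is new or still open speak of the compounds shown alone.

Measured so far:
compound 1 `COc1ccc(-c2cn(-c3cccc(C(=O)/C=C/c4cc(OC)c(OC)c(OC)c4)c3)c(=O)[nH]2)cc1` — 1420 nM
compound 2 `COc1ccc(-c2cn(-c3cccc(C(=O)/C=C/c4ccc(O)c(OC)c4)c3)c(=O)[nH]2)cc1` — 1770 nM

Working notes. Within the data shown here, in a functional assay on KM12 cells (Homo sapiens) for inhibition (a lower number here means a stronger inhibitor of growth, a higher number a weaker inhibitor of growth), compound 1 gives the lowest of the two numbers, with compound 2 nearest; the one measured step, a 1.2-fold higher number from compound 1 to compound 2 (0.10 log units; within the scatter), concerns the aryl on the double-bonded chain carbon and is within the scatter. Compound 3 `COc1cc(/C=C/C(=O)c2cccc(-n3cc(-c4cc(OC)c(OC)c(OC)c4)[nH]c3=O)c2)cc(OC)c1OC` is not yet measured. It differs from compound 1 in one place: 3,4,5-trimethoxyphenyl in place of 4-methoxyphenyl on an aromatic carbon. Among the measured compounds shown here, no measured step touches this aromatic carbon of the five-membered ring, so the only guide is the flat behaviour of compound 1 and compound 2 at the other aryl. For compound 3, therefore, no step beyond the scatter is expected in this assay; the estimate is 1400 nM, in the range 500 nM to 4000 nM, corresponding to an expected step of a 1.0-fold lower number from compound 1 to compound 3 (0.01 log units; within the scatter).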

Compound 3, concentration for 50% growth inhibition: 1120 nM
Compound 3: the middle estimate sits 1.3-fold (0.10 log units) above what was measured; low and high end bracket the measured number.
By their numbers in this assay, from the lowest: compounds 3, 1 and 2 (each within the scatter of the next).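

In this assay, among these compounds, putting 3,4,5-trimethoxyphenyl in place of 4-methoxyphenyl on the aromatic carbon of the five-membered ring gives a 1.3-fold lower number from compound 1 to compound 3 (0.10 log units; within the scatter), the first reading at this position. The aryl here can thus go from 8 to 12 heavy atoms with the number staying within the scatter, and the same holds for the one change at the other aryl, a 1.2-fold higher number from compound 1 to compound 2 (0.10 log units; within the scatter), so neither change shown separates the compounds. Nothing available accounts for this flat behaviour.

Both aryl groups shown at this aromatic carbon carry methoxy groups, so it remains open whether a different group there, such as an amine, a carboxylic acid or a longer chain, would give a step beyond the scatter. Also open, as far as these compounds go, is whether the flat behaviour extends beyond this assay.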